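A Dichloropyridinyl Ether Weighed Against Its Solubility Neighbours

This account rests on a few compounds, and the source may have more. Where it says the series, first, only, none or still open, it means among the compounds named here.

For the measured compounds named here, compound 3 `Cn1c(COc2cccc(C(=O)O)c2)nc2ccc(Oc3cccc(Cl)n3)cc21` gives 7.7 ug/mL in a physicochemical assay for solubility, read by HPLC, measured as thermodynamic solubility, with a stated time of 4 h, at pH 6.8 (on this read-out lower numbers stand for lower solubility and higher numbers for higher solubility), the highest of the three numbers measured so far. Compound 1 `Cc1ccc(Oc2ccc3nc(COc4cccc(C(=O)O)c4)n(C)c3n2)cc1F` gives 5.2 ug/mL, a gap from compound 3 that lies within the scatter. Compound 2 `Cc1cc(C)cc(Oc2ccc3nc(COc4cccc(C(=O)O)c4)n(C)c3n2)c1` gives 0.5 ug/mL, a number clearly below that of compound 3. Going by the values given here, the only step between compounds that differ in a single place is a 10-fold lower number from compound 1 to compound 2 (1.02 log units; beyond the scatter), which shows that an exchange of the aryl group on the ether oxygen can shift this read-out by a large amount. Compound 4 `Cn1c(COc2cccc(C(=O)O)c2)nc2ccc(Oc3ncc(Cl)cc3Cl)cc21` differs from compound 3 as follows: 3,5-dichloropyridin-2-yl in place of 6-chloropyridin-2-yl on an oxygen on an aromatic ring. Among the compounds with values here, no measured step covers this exact exchange; the step from compound 1 to compound 2 concerns the same position but other groups, so it serves only as a sign that such exchanges can be large. A modest lower step is expected, a 2.6-fold lower number from compound 3 to compound 4 (0.41 log units; beyond the scatter), smaller than that earlier one. Compound 4 is therefore estimated at 3 ug/mL, within a range from 0.8 ug/mL to 10 ug/mL.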

Compound 4, solubility: 9.9 ug/mL
Beside the measured number, compound 4's estimate is 3.3-fold (0.52 log units) below it; measured number inside the range.
By their numbers in this assay, from the lowest: compound 2; then compounds 1, 3 and 4 (each within the scatter of the next).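

In this assay the exchange of 6-chloropyridin-2-yl for 3,5-dichloropyridin-2-yl on an oxygen on an aromatic ring gives a 1.3-fold higher number from compound 3 to compound 4 (0.11 log units; within the scatter) and so does not separate the two compounds. For the compounds shown here, the only earlier step at this place, a 10-fold lower number from compound 1 to compound 2 (1.02 log units; beyond the scatter), showed that an aryl exchange on the ether oxygen can be large, whereas this pair shows that an exchange there, with 2 chlorine atoms entering where 1 leaves, need not be. Nothing measured here accounts for this outcome.

As far as these compounds go, it remains open whether an amine or a carboxylic acid in place of the chlorine of the 6-chloropyridin-2-yl group would keep the number in this range. Also open, from the compounds shown here alone, is whether 3,5-dimethylphenyl on the core of compound 3 would give a step as large as the one seen on the core of compound 1.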